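The compounds below may be only part of what the source reports. "The series", "measured", "known", "first", "only" and "open" are said of these compounds alone.

Compound 1 `NS(=O)(=O)CC(=O)NCCSc1nonc1/C(=N/O)Nc1ccc(F)c(Br)c1`: 0.758 h
Compound 2 `CS(=O)(=O)CC(=O)NCCSc1nonc1/C(=N/O)Nc1ccc(F)c(C(F)F)c1`: 1.59 h
Compound 3 `CC1(C(=O)NCCSc2nonc2/C(=N/O)Nc2ccc(F)c(C(F)F)c2)CCN1`: > 3 h

All three values come from an ADME assay on isolated protein for pharmacokinetics, with UDP-glucuronosyltransferase 1A9 (Homo sapiens) as the target, read by LC-MS, with a stated time of 60 min, at 37 degrees C, tested at 1 uM, in the presence of a further agent that is not named here; on this read-out lower numbers stand for a shorter-lived compound and higher numbers for a longer-lived compound. The value of compound 3 is a limit of the assay and not a number, as the limit of > 3 h in this assay, at which 1 of the 3 values shown sits, shows. Going by the values given here, the only measured step that changes one place is an at least 1.8-fold higher number from compound 2 to compound 3 (0.27 log units; that floor lies within the scatter). Compound 4 `CC(C)(O)CC(=O)NCCSc1nonc1/C(=N/O)Nc1ccc(F)c(C(F)F)c1` differs from compound 3 by a group of 5 heavy atoms (4 carbon, 1 oxygen; no ring) in place of a group of 5 heavy atoms (4 carbon, 1 nitrogen; one four-membered non-aromatic ring with 1 hetero atom), on a carbonyl carbon. Among the compounds with values here, no measured step carries this exact change; the step from compound 2 to compound 3 shows only that replacing a group without a ring by the four-membered ring gave a higher number, with its floor within the scatter. Compound 4 is therefore expected to show an at least 1.2-fold lower number from compound 3 to compound 4 (0.09 log units; that floor lies within the scatter). The estimate for compound 4 is 2.4 h, with a range from 1.2 h to 3 h.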

Compound 4, half-life: > 3 h
Compound 4 gave a limit, no number; the forecaster's own chance of this, stated with the estimate: 35%; at least 1.2-fold (0.09 log units) between middle value and limit.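

In this assay compound 4 gives > 3 h, which is a limit of the assay and not a number. Putting 1-hydroxy-1-methylethyl in place of methylsulfonyl gives an at least 1.8-fold higher number from compound 2 to compound 4 (0.27 log units; that floor lies within the scatter). A group with no ring on the carbonyl carbon therefore reaches the same limit as the four-membered ring of compound 3: the limit of > 3 h in this assay, at which 2 of the 4 values shown sit.

The step between compound 3 and compound 4 cannot be read, so the two groups cannot be ranked. On these data alone, whether a carboxylic acid or a simple amine at this place would also reach that limit stays open.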